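The source may hold more compounds than are shown below. What is called first, only, known or untested is meant among the compounds shown, and "the series" means these compounds.

Series notes. Compound 1 `CCCC[C@@H](O)C(=O)N1N=CC[C@H]1C(=O)NCc1cc(Cl)ccc1-n1cnnn1` is the reference point for the present step. Among the compounds with values here, in a physicochemical assay for solubility, measured as kinetic solubility, at pH 6.8 (a higher number here means a more soluble compound, a lower number a less soluble compound), compound 1 gives 59000 nM, the lowest of the two numbers so far, with compound 2 `CC(C)(C)[C@@H](O)C(=O)N1C[C@@H]2C[C@@H]2[C@H]1C(=O)NCc1cc(Cl)ccc1-n1cnnn1` nearest: compound 2 gives 97000 nM, a gap that lies within the scatter, so no order between the two is claimed. Compound 3 `CCCC(=O)O[C@@H](C(=O)N1N=CC[C@H]1C(=O)NCc1cc(Cl)ccc1-n1cnnn1)c1ccc(F)cc1` sits at a limit of this assay rather than at a number, compound 3 giving < 1000 nM; (the limit of < 1000 nM in this assay, at which 1 of the 3 values shown sits).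

The unmeasured compound 4 `O=C(NCc1cc(Cl)ccc1-n1cnnn1)[C@@H]1CC=NN1C(=O)[C@H](O)c1ccccc1` differs from compound 1 in one place: phenyl in place of butyl on a saturated chain carbon bound to a carbonyl carbon and an oxygen on a saturated carbon. Within the data shown here, no measured pair in the set separates this change on its own, so its size is not known from the data; compound 3 also carries a phenyl-type group at the same carbon, but with a further change at the oxygen, and it shows only a limit, which fixes nothing about the phenyl alone.

Expectation: in this assay a modest drop, not clearly beyond the scatter, is expected from compound 1 to compound 4, with a 1.7-fold lower number from compound 1 to compound 4 (0.23 log units; within the scatter) the step the estimate implies. For compound 4 the expected value in this assay is 35000 nM, with a range from 10000 nM to 90000 nM.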

Compound 4, solubility: 98000 nM
For compound 4 the middle estimate is 2.8-fold (0.45 log units) below the measured one, and the stated range ends below it.
By their numbers in this assay, from the lowest: compounds 1, 2 and 4 (each within the scatter of the next). At a limit, below all of these: compound 3.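

In this assay, within the data shown here, the pair of compound 1 and compound 4 is the first to separate one change at this position, phenyl in place of butyl on a saturated chain carbon bound to a carbonyl carbon and an oxygen on a saturated carbon, and it gives a 1.7-fold higher number from compound 1 to compound 4 (0.22 log units; within the scatter) for that change alone. At this position, then, a chain with no ring and a six-membered aromatic ring of carbon only cannot be told apart in this read-out, and compound 4 keeps the hydroxyl and the core of compound 1 without reaching a limit of the assay. The data shown give no cause for this step.

Compound 3 stands at a limit, < 1000 nM, and it differs from compound 4 in more than one place, so the phenyl-type group and the change at the oxygen cannot be separated from that compound. Going by these compounds, whether this tolerance extends beyond butyl and phenyl stays open, since a single step says nothing about a longer chain, an amine or a carboxylic acid on the same carbon.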